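Ring closure of the basic amine in the amide series

The source may hold more compounds than are shown below. What is called first, only, known or untested is meant among the compounds shown, and "the series" means these compounds.

Compound 1 `Oc1ccc(-c2nc3cc(C(F)(F)F)ccc3[nH]2)cc1`, compound 2 `O=C(CN1CCCC1)Nc1ccc(-c2nc3ccccc3[nH]2)cc1`, compound 3 `CCN(CC)CC(=O)Nc1ccc(-c2nc3cc(C(F)(F)F)ccc3[nH]2)cc1` and the unmeasured compound 4 `O=C(CN1CCCC1)Nc1ccc(-c2nc3cc(C(F)(F)F)ccc3[nH]2)cc1` share the core of compound 1. In an ADME assay on BHK cells (Mesocricetus auratus) for cytotoxicity, read by MTT assay, with a stated time of 96 h (on this read-out higher numbers stand for lower toxicity in this test and lower numbers for higher toxicity in this test), compound 1 gives only a limit, > 100000 nM. In this assay compound 2 gives 55000 nM. In this assay compound 3 gives 23000 nM, the lowest of the two numbers measured, with compound 2 the nearest value beyond the scatter. Among the compounds with values here, the one measured step is an at least 4.3-fold lower number from compound 1 to compound 3 (0.63 log units; beyond the scatter); it rests on (the limit of > 100000 nM in this assay, at which 1 of the 3 values shown sits), so only its lower bound is known.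

The step to compound 4 is pyrrolidin-1-yl in place of diethylamino on a saturated chain carbon bound to a carbonyl carbon. Within the data shown here, no measured step covers this change; compound 2 and compound 3 differ in two places at once, so their two values alone cannot be attributed to the amine. The change keeps the count of heavy atoms, donors and acceptors, and nothing measured points in either direction. In this assay compound 4 is therefore expected to sit close to compound 3, at an estimated 28000 nM, in the range 12000 nM to 70000 nM. The expected step is a 1.2-fold higher number from compound 3 to compound 4 (0.09 log units; within the scatter), not beyond the scatter.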

Compound 4, half-maximal cytotoxic concentration: 29000 nM
Beside the measured number, compound 4's estimate is 1.0-fold (0.02 log units) below it, and the stated range covers the measured number.
By their numbers in this assay, from the lowest: compounds 3, 4 and 2 (each within the scatter of the next, the first and the last beyond it). At a limit, above all of these: compound 1.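

The amine can now be read on its own. In this assay the step is a 1.3-fold higher number from compound 3 to compound 4 (0.10 log units; within the scatter) with nothing else altered, so closing diethylamino into pyrrolidin-1-yl on a saturated chain carbon bound to a carbonyl carbon leaves the number within the scatter. Within the data shown here, the trifluoromethyl group can also be read on its own for the first time: in place of hydrogen on an aromatic carbon it gives a 1.9-fold lower number from compound 2 to compound 4 (0.28 log units; within the scatter) and also stays within the scatter. With the pyrrolidine amide in place of hydroxy the step is an at least 3.4-fold lower number from compound 1 to compound 4 (0.53 log units; beyond the scatter) and goes the same way as the step to the diethylamino amide, but only its lower bound is known: the limit of > 100000 nM in this assay, at which 1 of the 4 values shown sits.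

Still open is whether a six-membered amine such as piperidin-1-yl or morpholin-4-yl, a primary amine, or a longer chain between the carbonyl and the amine would also stay within the scatter of these compounds. Also open, on these data alone, is whether another group in place of trifluoromethyl on the shared core, such as chlorine or nitrile, would behave as trifluoromethyl does.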